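Swapping the ring on the core nitrogen for a hydroxylated chain

A few compounds are considered here, and "the series" means these few. Any claim that something is new, unique, unknown or untested is made for them only; others in the source may bear on it.

Of the compounds shown here, two of a shared core have been tested in an assay on isolated protein for inhibition of proto-oncogene tyrosine-protein kinase receptor Ret (Homo sapiens), read by radiometric assay and 33P incorporation, in the presence of a further agent that is not named here; a higher number here means a weaker inhibitor, a lower number a stronger inhibitor. Compound 1 `Nc1ncnc2c1c(-c1cc(C3CC3)on1)nn2C1CCOCC1` gives 5 nM in this assay, the lowest of the two numbers. Compound 2 `CC(C)c1cc(-c2nn(C(C)C)c3ncnc(N)c23)no1` gives 41 nM in this assay, a higher number, and that gap lies beyond the usual scatter. For the measured compounds named here, the two compounds differ in more than one place, so their values show only that compound 1 is the stronger inhibitor here, not what any single change does.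

Compound 3 `CC(C)(O)Cn1nc(-c2cc(C3CC3)on2)c2c(N)ncnc21` has not yet been measured. It differs from compound 1 in one place: 2-hydroxy-2-methylpropyl in place of oxan-4-yl on an aromatic nitrogen. Going by the values given here, no measured pair in this set isolates a change at that position, so there is nothing to lean on apart from the starting value of compound 1.

The expectation for compound 3 is therefore modest: a step from compound 1 to compound 3 of about a 2.0-fold higher number from compound 1 to compound 3 (0.30 log units; within the scatter) in this assay, with the direction uncertain and possibly no change beyond the scatter. Compound 3 is estimated at 10 nM in this assay, within a range from 3 nM to 40 nM.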

Compound 3, half-maximal inhibitory concentration: 68 nM
Estimate against measurement, compound 3: 6.8-fold (0.83 log units) below; measured number outside the range, above it.
By their numbers in this assay, from the lowest: compound 1; then compounds 2 and 3 (each within the scatter of the next).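

In this assay the step of a 14-fold higher number from compound 1 to compound 3 (1.13 log units; beyond the scatter) comes from replacing oxan-4-yl with 2-hydroxy-2-methylpropyl on the aromatic nitrogen, and it shows that inhibition depends on what this position carries, which the earlier two compounds could not show because they differ in more than one place. This single change does several things at once: it opens the six-membered non-aromatic ring into a chain with no ring and it adds a hydrogen-bond donor, while the count of hydrogen-bond acceptors stays the same, so the step cannot say which of these differences matters. Nothing measured here explains why the number rises.

As far as these compounds go, it remains open whether the loss follows the missing ring or the added hydroxyl group, and the plain 2-methylpropyl chain without the hydroxyl, or a cyclohexyl ring without the ring oxygen, on the same nitrogen would help to separate the two. Also open, from the compounds shown here alone, is how a longer chain ending in a hydroxyl group, or an amine in its place, would compare with compound 1 on this core.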